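The source may hold more compounds than are shown below. What is called first, only, known or untested is meant among the compounds shown, and "the series" means these compounds.

Compound 1 `CC1=CC[C@H](C(C)(C)NC(=S)N/N=C/c2ccccc2)CC1` gives 6300 nM in a functional assay on K562 cells (Homo sapiens) for inhibition, read by sulforhodamine B assay, with a stated time of 48 h; a higher number here means a weaker inhibitor of growth, a lower number a stronger inhibitor of growth.
Compound 2 `COc1ccc(/C=N/NC(=S)NC(C)(C)[C@H]2CC=C(C)CC2)cc1` gives 1500 nM in this assay.
Compound 3 `CC1=CC[C@H](C(C)(C)NC(=S)N/N=C/c2ccccc2O)CC1` gives 800 nM in this assay.

Among these three numbers compound 2 stands second highest. Its nearest neighbour is compound 3, and the step of a 1.9-fold lower number from compound 2 to compound 3 (0.27 log units; within the scatter) lies within the scatter, so no order between the two can be claimed. Its furthest neighbour is compound 1, and the step of a 4.2-fold lower number from compound 1 to compound 2 (0.62 log units; beyond the scatter) lies beyond the scatter.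

The unmeasured compound 4 `CC1=CC[C@H](C(C)(C)NC(=S)N/N=C/c2ccc(N(C)C)cc2)CC1` differs from compound 2 by a single change: dimethylamino in place of methoxy on an aromatic carbon. Among the compounds with values here, no measured step swaps one such group for another on the same aromatic carbon. The step that touches that carbon is a 4.2-fold lower number from compound 1 to compound 2 (0.62 log units; beyond the scatter), where methoxy appears in place of hydrogen; the step of a 7.9-fold lower number from compound 1 to compound 3 (0.90 log units; beyond the scatter) concerns hydroxy on a different aromatic carbon. Both measured departures from the unsubstituted ring of compound 1 gave modestly lower numbers. For the swap from methoxy to dimethylamino the data give no direct guide, and the expected step of a 1.5-fold lower number from compound 2 to compound 4 (0.18 log units; within the scatter) in this assay is therefore small and may not exceed the scatter. On that basis compound 4 is estimated at 1000 nM, with a range from 300 nM to 3500 nM.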

Compound 4, concentration for 50% growth inhibition: 22600 nM
Compound 4: the middle estimate sits 23-fold (1.35 log units) below what was measured; measured number outside the range, above it.
By their numbers in this assay, from the lowest: compounds 3 and 2 (each within the scatter of the next); then compound 1; then compound 4.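

At the aromatic carbon para to a large group, methoxy and dimethylamino proved far from interchangeable in this assay, with a 15-fold higher number from compound 2 to compound 4 (1.18 log units; beyond the scatter), even though the two groups match in hydrogen-bond donors and acceptors and neither carries a net charge. Adding a substituent to this carbon also does not always lower the number: dimethylamino, set against the unsubstituted ring, gives a 3.6-fold higher number from compound 1 to compound 4 (0.55 log units; beyond the scatter), whereas methoxy at the same carbon gives a 4.2-fold lower number from compound 1 to compound 2 (0.62 log units; beyond the scatter), so compound 4 goes against the direction that compound 2 and compound 3 had shown. Nothing available accounts for the gap between these two groups.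

As far as these compounds go, what a primary amine or a methylamino group would give at this carbon remains open, and with it whether the higher number goes with the nitrogen itself or with its two methyl groups. Also open, from the compounds shown here alone, is how dimethylamino would behave on the aromatic carbon that carries hydroxy in compound 3, so the result speaks for one position only.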